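The source may hold more compounds than are shown below. What is called first, only, known or untested is meant among the compounds shown, and "the series" means these compounds.

Measured so far in a functional assay on KYSE-450 cells (Homo sapiens) for inhibition, read by CCK-8 assay, with a stated time of 48 h; a higher number here means a weaker inhibitor, a lower number a stronger inhibitor:
compound 1 `CCN1CCN(CC(=O)N(Cc2ccc(OC)cc2)c2cc(OC)c(OC)c(OC)c2)CC1` gives 16100 nM;
compound 2 `COc1ccc(CN(C(=O)CN2CCN(C(C)=O)CC2)c2cc(OC)c(OC)c(OC)c2)cc1` gives 10800 nM;
compound 3 `CCN1CCN(C(=S)SCC(=O)N(Cc2ccc(OC)c(O)c2)c2cc(OC)c(OC)c(OC)c2)CC1` gives 320 nM.

Compound 3 gives the lowest number of the three, and its gaps to compound 1 and to compound 2 are both beyond the scatter. The difference between the core of compound 1 and the core of compound 3 is not broken down here.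

Within the core of compound 1, the change acetyl in place of ethyl on an amine nitrogen in a ring gave the step of a 1.5-fold lower number from compound 1 to compound 2 (0.17 log units; within the scatter).

Compound 4 `COc1ccc(CN(C(=O)CSC(=S)N2CCN(C(C)=O)CC2)c2cc(OC)c(OC)c(OC)c2)cc1O` has not been measured. It differs from compound 3 by acetyl in place of ethyl on an amine nitrogen in a ring, the same change as from compound 1 to compound 2, at the same place in the ring.

Expectation: since the one measured instance of this change, compound 1 to compound 2, moved the number only by a 1.5-fold lower number from compound 1 to compound 2 (0.17 log units; within the scatter), the step from compound 3 to compound 4 in this assay is expected to stay small, about a 1.2-fold lower number from compound 3 to compound 4 (0.09 log units; within the scatter). Compound 4 is estimated at 260 nM, with the range 100 nM to 800 nM.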

Compound 4, half-maximal inhibitory concentration: 210 nM
Compound 4: middle estimate off by 1.2-fold (0.09 log units), on the high side; low and high end bracket the measured number.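

In this assay, acetyl in place of ethyl on an amine nitrogen in a ring gave a 1.5-fold lower number from compound 3 to compound 4 (0.18 log units; within the scatter). Set beside the earlier step, the change reads the same on the two cores: the same change on two cores in this assay, a 1.5-fold lower number (0.17 log units; within the scatter) from compound 1 to compound 2 and a 1.5-fold lower number (0.18 log units; within the scatter) from compound 3 to compound 4, 1.0-fold (0.01 log units) apart, within the scatter of two such steps. This shows that, on these two cores, the exchange of 4-ethylpiperazin-1-yl for 4-acetylpiperazin-1-yl leaves the number within the scatter, so the two groups cannot be told apart in this read-out; it does not show that the change has a real effect of its own, and two pairs of compounds make no rule for the whole series.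

Open, as far as these compounds go, is whether other groups on that ring nitrogen, such as a sulfonyl group, a carboxylic acid or a longer chain, would also leave the number in place. Also open is which part of the difference between the core of compound 1 and the core of compound 3 accounts for the gap between them, as no pair shown separates those parts.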